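The compounds below may be only part of what the source reports. "The series", "measured", "known", "first", "only" and "open" are said of these compounds alone.

Measured compounds:
compound 1 `CC(=O)N(C)c1ccc(Nc2nccc(-c3cccnc3)n2)cc1` — 900 nM
compound 2 `CC(=O)N(C)c1ccc(Nc2nccc(-c3ccccn3)n2)cc1` — 1800 nM
compound 3 `c1cc(Nc2nccc(-c3ccco3)n2)cc(OCCn2ccnc2)c1` — 200 nM

In a functional assay for inhibition, with Homo sapiens as the target (a lower number here means a stronger inhibitor, a higher number a weaker inhibitor), compound 1 stands second highest of the three numbers. Its nearest neighbour is compound 2, reached by a 2.0-fold higher number from compound 1 to compound 2 (0.30 log units; within the scatter). Compound 3 is furthest off; its number is lower than that of compound 1 and the gap between the two lies beyond the scatter, but compound 3 differs from compound 1 in more than one place, so no single step can be read from that pair.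

Compound 4 `COc1ccc(Nc2nccc(-c3cccnc3)n2)cc1` is not yet measured. It differs from compound 1 as follows: methoxy in place of acetyl(methyl)amino on an aromatic carbon. Among the measured compounds shown here, no measured step bears on this change: the only single step known, from compound 1 to compound 2, alters a different group on a different ring and stays within the scatter, so it says nothing about an exchange of acetyl(methyl)amino for methoxy on the aromatic carbon para to a large group. With nothing to anchor it, the expected outcome in this assay is a step of a 1.5-fold lower number from compound 1 to compound 4 (0.18 log units; within the scatter), not clearly beyond the scatter in either direction. For compound 4 the estimated value in this assay is 600 nM, within a range of 200 nM to 2000 nM.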

Compound 4, half-maximal inhibitory concentration: 1700 nM
The estimate for compound 4 lay 2.8-fold (0.45 log units) below the measured number, within the range that was stated.
By their numbers in this assay, from the lowest: compound 3; then compounds 1, 4 and 2 (each within the scatter of the next).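

Methoxy in place of acetyl(methyl)amino on the aromatic carbon para to a large group gives a 1.9-fold higher number from compound 1 to compound 4 (0.28 log units; within the scatter) in this assay. Among the compounds shown here, this is the first reading at this place, as the earlier step concerned the other aromatic substituent, and it shows that going from 5 heavy atoms to 2 and losing the double bond outside aromatic rings, with 1 hydrogen-bond acceptor on each side, does not move the number beyond the scatter. Nothing measured on these compounds offers an explanation for this outcome.

Still open, on these data alone, is whether an amine, a carboxylic acid or a longer chain at this place would stand apart from methoxy and acetyl(methyl)amino in this assay. As far as these compounds go, the exchange of pyridin-3-yl for pyridin-2-yl is also read only with acetyl(methyl)amino present, so its outcome with methoxy remains unknown.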